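Aryl swap on the thiazole: 2-chlorophenyl to 4-fluorophenyl

The source may hold more compounds than are shown below. What is called first, only, known or untested is meant among the compounds shown, and "the series" means these compounds.

Three compounds of this series share one core and differ only in the aryl group on the thiazole carbon. Compound 1 `Cc1nc(-c2cccs2)sc1COc1ccc2c(c1)OCC2CC(=O)O` gives 35.2% in a functional assay on CHO cells for agonist activity at Free fatty acid receptor 1 (Homo sapiens), read by FLIPR and calcium flux, tested at 100 nM; on this read-out lower numbers stand for a weaker effect and higher numbers for a stronger effect at the one concentration tested. Compound 2 `Cc1nc(-c2ccsc2)sc1COc1ccc2c(c1)OCC2CC(=O)O` gives 56.5%. Compound 3 `Cc1nc(-c2ccccc2Cl)sc1COc1ccc2c(c1)OCC2CC(=O)O` gives 12.4% and stands lowest of the three; the nearest number is that of compound 1, and the step of a number 22.8 percentage points lower from compound 1 to compound 3 (beyond the scatter) is beyond the scatter, as is the larger step of a number 44.1 percentage points lower from compound 2 to compound 3 (beyond the scatter). The step of a number 21.3 percentage points higher from compound 1 to compound 2 (beyond the scatter) shows that even a change within the thiophene ring moves the read-out modestly.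

Compound 4 `Cc1nc(-c2ccc(F)cc2)sc1COc1ccc2c(c1)OCC2CC(=O)O` is not yet measured. The change is 4-fluorophenyl in place of 2-chlorophenyl on an aromatic carbon, on an aromatic carbon of the five-membered ring with one nitrogen and one sulfur. Among the compounds with values here, no measured step exchanges one substituted phenyl for another, so nothing bears on it directly. The two steps into compound 3 show that aryl swaps at this position move the number modestly to largely, and compound 3 sits at the bottom of the range seen so far, so a step upward beyond the scatter is plausible but its size is uncertain.

For compound 4 a value of 33% is expected, within 10% to 62%, which corresponds to an estimated step of a number 20.6 percentage points higher from compound 3 to compound 4 (beyond the scatter).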

Compound 4, a percentage reported as activity, at one concentration (the size of the read-out at that concentration, not a potency): 61.6%
The estimate for compound 4 lay 28.6 percentage points below the measured number; low and high end bracket the measured number.
By their numbers in this assay, from the lowest: compound 3; then compound 1; then compounds 2 and 4 (each within the scatter of the next).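

In this assay, the exchange of one substituted phenyl for another at this thiazole carbon gives a number 49.2 percentage points higher from compound 3 to compound 4 (beyond the scatter), with the heavy atom count of the group unchanged, so a phenyl group here is compatible with a high read-out and the low number of compound 3 belongs to 2-chlorophenyl rather than to phenyl groups as a whole. With a number 5.1 percentage points higher from compound 2 to compound 4 (within the scatter), 4-fluorophenyl and thiophen-3-yl cannot be told apart in this read-out, whereas a number 26.4 percentage points higher from compound 1 to compound 4 (beyond the scatter) separates 4-fluorophenyl from thiophen-2-yl. Nothing measured on these compounds offers an explanation for these steps.

Compound 3 and compound 4 differ in both the halogen and its place on the phenyl, so the two contributions remain unseparated; 4-chlorophenyl and 2-fluorophenyl would pull them apart. On these data alone, whether unsubstituted phenyl or 4-methoxyphenyl would hold the number at the level of compound 4 also remains open, and a read-out at one concentration says nothing about potency.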